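The source may report more compounds than this note shows. Statements on the series, on what has been measured and on what is new or still open speak of the compounds shown alone.

Four compounds share a core, and the measured ones all carry either an amino or a nitro group on one of the aromatic rings. Compound 1 `COc1cc(OC)c(/C=C/S(=O)(=O)Cc2ccc(F)c(N)c2)c(OC)c1` bears the amino group, and compound 2 `COc1cc(OC)c(/C=C/S(=O)(=O)Cc2ccc(F)c([N+](=O)[O-])c2)c(OC)c1` the nitro group in the same place. In a functional assay on K562 cells (Homo sapiens) for cytotoxicity, read by trypan blue exclusion, with a stated time of 96 h (on this read-out lower numbers stand for stronger inhibition and higher numbers for weaker inhibition), compound 1 gives 2500 nM, while compound 2 gives 25000 nM. The change between them is amino in place of nitro on an aromatic carbon, and it brought a 10-fold lower number from compound 2 to compound 1 (1.00 log units; beyond the scatter).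

Compound 3 `COc1cc(OC)c(/C=C/[S+]([O-])Cc2ccc(OC)c([N+](=O)[O-])c2)c(OC)c1` also carries the nitro group, but on a different core; how the core of compound 3 differs from the core of compound 2 is not broken down here. In this assay compound 3 gives 15000 nM, a number close to that of compound 2 and well apart from that of compound 1.

Compound 4 `COc1cc(OC)c(/C=C/[S+]([O-])Cc2ccc(OC)c(N)c2)c(OC)c1` has not yet been measured. It differs from compound 3 by amino in place of nitro on an aromatic carbon. Among the measured compounds shown here, this is the same kind of change as the one from compound 2 to compound 1, not the same change: in compound 1 the amino group is ortho to a fluoro group, whereas in compound 4 it is ortho to a methoxy group, and in both it is meta to a large group. Because the earlier exchange gave a 10-fold lower number from compound 2 to compound 1 (1.00 log units; beyond the scatter), a step of similar size is expected in this assay, namely a 7.5-fold lower number from compound 3 to compound 4 (0.88 log units; beyond the scatter). The value expected for compound 4 is 2000 nM. For compound 4 the estimate is expected to fall between 700 nM and 6000 nM.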

Compound 4, half-maximal inhibitory concentration: 20 nM
Estimate against measurement, compound 4: 100-fold (2.00 log units) above; measured number below the stated range.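

In this assay, amino in place of nitro on an aromatic carbon again lowers the number, and on the core of compound 3 it brought a 750-fold lower number from compound 3 to compound 4 (2.88 log units; beyond the scatter). The direction of the change therefore carries over from one core to the other in these two pairs, but its size does not, so the step seen on one core is a poor guide to the size of the step on the other: the same change on two cores in this assay, a 10-fold lower number (1.00 log units; beyond the scatter) from compound 2 to compound 1 and a 750-fold lower number (2.88 log units; beyond the scatter) from compound 3 to compound 4, 75-fold (1.88 log units) apart, beyond the scatter of two such steps. The two cores differ in more than one place, among them a fluoro group in compound 1 against a methoxy group in compound 4, so these two pairs cannot show which difference goes with the larger step, nor why the step is larger.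

The compounds shown leave open whether the large step belongs to the methoxy group or to the rest of the core of compound 4, a question that a compound with a fluoro group on the core of compound 3 could help to settle. They also leave open how a hydroxyl, an acetamide or a dimethylamino group in place of the amino group would read in this assay on either core.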